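This account rests on a few compounds, and the source may have more. Where it says the series, first, only, none or still open, it means among the compounds named here.

Of the compounds shown here, three built on one shared core have been measured in a functional assay on HeLa cells (Homo sapiens) for antiproliferative activity, read by MTT assay, with a stated time of 48 h; a lower number here means a stronger inhibitor, a higher number a weaker inhibitor. Compound 1 `COc1ccccc1C(=O)Nc1nnc(SCC(=O)Nc2ccc(C)cn2)s1` reaches only the limit of the assay, returning > 80000 nM. Compound 2 `COc1ccccc1C(=O)Nc1nnc(SCC(=O)Nc2ccc(Cl)cn2)s1` likewise gives a limit, > 80000 nM. Compound 3 `COc1ccccc1C(=O)Nc1nnc(SCC(=O)Nc2c(C)ccnc2Cl)s1` also yields only a limit, > 80000 nM. The steps a step that the two limits leave unreadable from compound 1 to compound 2, a step that the two limits leave unreadable from compound 1 to compound 3 and a step that the two limits leave unreadable from compound 2 to compound 3 therefore cannot be sized, and compound 3 stands among values that all sit at the same limit (the limit of > 80000 nM in this assay, at which 3 of the 3 values shown sit). Compound 4 `Cc1ccnc(Cl)c1NC(=O)CSc1nnc(NC(=O)CCl)s1` differs from compound 3 by chloromethyl in place of 2-methoxyphenyl on a carbonyl carbon. For the measured compounds named here, none of the measured steps touches this carbonyl position, and none carries a readable size, so no change beyond the scatter can be anticipated. Compound 4 is accordingly expected to give about 80000 nM in this assay, within 15000 nM to 400000 nM. This estimate means an expected step of a number no higher from compound 3 to compound 4 (the limit leaves the size open), read as no real movement.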

Compound 4, half-maximal inhibitory concentration: 70500 nM
Beside the measured number, compound 4's estimate is 1.1-fold (0.05 log units) above it; measured number inside the range.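

With chloromethyl on this carbonyl carbon, the series gives its first number rather than a limit: in this assay compound 4 gives 70500 nM. From the compounds shown here alone, the change reads as an at least 1.1-fold lower number from compound 3 to compound 4 (0.05 log units; that floor lies within the scatter), so only a floor is known and its true size stays open. Compound 1, compound 2 and compound 3 remain limits: the limit of > 80000 nM in this assay, at which 3 of the 4 values shown sit.

The compounds shown leave open whether methyl, aminomethyl or a longer chain on this carbonyl carbon would also give a number. They also leave open how chloromethyl behaves with 5-chloropyridin-2-yl on the amide-type nitrogen.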